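The source may hold more compounds than are shown below. What is called first, only, known or untested is meant among the compounds shown, and "the series" means these compounds.

Series notes. In a functional assay on PANC-1 cells (Homo sapiens) for inhibition, read by MTT assay, with a stated time of 48 h (on this read-out lower numbers stand for stronger inhibition and higher numbers for weaker inhibition), compound 1 `Cn1c(=O)c2[nH]c(SCC(=O)c3ccccc3)nc2n(C)c1=O` gives 4900 nM. Compound 2 `Cn1c(=O)[nH]c2nc(SCC(=O)c3ccccc3)[nH]c2c1=O` differs from it by hydrogen in place of methyl on an aromatic nitrogen and in this assay compound 2 gives 9400 nM; the step is a 1.9-fold higher number from compound 1 to compound 2 (0.28 log units; within the scatter). Compound 3 `Cn1c(=O)c2[nH]c(SC/C(=N/O)c3ccccc3)nc2n(C)c1=O` carries a different core, and the difference between the two cores is not broken down here; in this assay compound 3 gives 5500 nM, a value within the scatter of compound 1 and compound 2. Compound 4 `Cn1c(=O)[nH]c2nc(SC/C(=N/O)c3ccccc3)[nH]c2c1=O` is not yet measured and differs from compound 3 by hydrogen in place of methyl on an aromatic nitrogen, the same change as from compound 1 to compound 2, made at the same place. Beside the measured step, a step of a 1.8-fold higher number from compound 3 to compound 4 (0.26 log units; within the scatter) is expected, resting on the single precedent of compound 1 and compound 2 and the value of compound 3. The estimate for compound 4 in this assay is 10000 nM, between 5000 nM and 22000 nM.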

Compound 4, half-maximal inhibitory concentration: 3600 nM
Compound 4: middle estimate off by 2.8-fold (0.44 log units), on the high side, outside the stated range (below it).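

In this assay, hydrogen in place of methyl on the aromatic nitrogen gives a 1.5-fold lower number from compound 3 to compound 4 (0.18 log units; within the scatter), and this step does not match the earlier one on the core of compound 1: the same change on two cores in this assay, a 1.9-fold higher number (0.28 log units; within the scatter) from compound 1 to compound 2 and a 1.5-fold lower number (0.18 log units; within the scatter) from compound 3 to compound 4, 2.9-fold (0.47 log units) apart, beyond the scatter of two such steps. The step seen on one core therefore did not carry over to the other in this assay, and a step from one core is a poor guide to the other in this series. Each step alone lies within the scatter, so neither core shows a clear effect of the change, and the data do not show why the two steps part.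

As far as these compounds go, whether a longer chain or an amine on that aromatic nitrogen would follow either step remains open. So does the behaviour of the same change on a third core.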